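A bulkier, aromatic substituent replaces tert-butyl

The source may report more compounds than this note shows. Statements on the series, on what has been measured and on what is new or still open speak of the compounds shown alone.

Of the compounds shown here, three sharing one core have been tested in a functional assay on HepG2 cells (Homo sapiens) for antiproliferative activity, read by MTT assay, with a stated time of 72 h; on this read-out lower numbers stand for stronger inhibition and higher numbers for weaker inhibition. Compound 1 `O=C1O[C@H]([C@@H](O)Cn2cc(-c3cccc(O)c3)nn2)C(OCc2ccccc2)=C1OCc1ccccc1` gives 62700 nM. Compound 2 `COc1ccccc1-c1cn(C[C@H](O)[C@H]2OC(=O)C(OCc3ccccc3)=C2OCc2ccccc2)nn1` reaches only the limit of the assay, > 100000 nM, so no number is known for it. Compound 3 `CC(C)(C)c1cn(C[C@H](O)[C@H]2OC(=O)C(OCc3ccccc3)=C2OCc2ccccc2)nn1` gives 29200 nM, the lowest of the two numbers; the nearest is compound 1, as the step of a 2.1-fold lower number from compound 1 to compound 3 (0.33 log units; beyond the scatter) shows. The step of an at least 3.4-fold lower number from compound 2 to compound 3 (0.53 log units; beyond the scatter) points the same way, though its size rests on (the limit of > 100000 nM in this assay, at which 1 of the 3 values shown sits).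

Compound 4 `O=C1O[C@H]([C@@H](O)Cn2cc(CNS(=O)(=O)c3ccc(Cl)cc3)nn2)C(OCc2ccccc2)=C1OCc1ccccc1` differs from compound 3 in one place: (((4-chlorophenyl)sulfonyl)amino)methyl in place of tert-butyl on an aromatic carbon. Both measured steps bear on this change: in each, exchanging a group carrying a six-membered aromatic ring for tert-butyl gave a lower number, so bringing such a ring back, here as part of an even larger group, is expected to raise the number. The expected step is a 2.2-fold higher number from compound 3 to compound 4 (0.35 log units; beyond the scatter). Compound 4 is therefore estimated at about 65000 nM, with a plausible range from 25000 nM to 170000 nM.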

Compound 4, half-maximal inhibitory concentration: 7510 nM
Estimate against measurement, compound 4: 8.7-fold (0.94 log units) above, and the stated range ends above it.
By their numbers in this assay, from the lowest: compound 4; then compound 3; then compound 1. At a limit, above all of these: compound 2.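

Placed on the aromatic carbon of the five-membered aromatic ring with 3 nitrogen, (((4-chlorophenyl)sulfonyl)amino)methyl gives the lowest number so far in this assay, with a 3.9-fold lower number from compound 3 to compound 4 (0.59 log units; beyond the scatter) and an 8.3-fold lower number from compound 1 to compound 4 (0.92 log units; beyond the scatter). Compounds 1, 2 and 3 alone suggested that tert-butyl was preferred over groups carrying a six-membered aromatic ring, but compound 4 carries such a ring and goes against that pattern, so the ring alone does not set the result at this position. The step of an at least 13-fold lower number from compound 2 to compound 4 (1.12 log units; beyond the scatter) is only a floor, set by a limit of the assay: the limit of > 100000 nM in this assay, at which 1 of the 4 values shown sits.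

The compounds shown do not reveal which part of the new group accounts for the lower number. A plain phenyl in place of 4-chlorophenyl, or a carbonyl in place of the sulfonyl, would help separate those parts.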